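A few compounds are considered here, and "the series" means these few. Any claim that something is new, unique, unknown or untested is made for them only; others in the source may bear on it.

Compound 1 `CC(C)N(C)c1ccc2cc(NC(=O)CCc3ccc(C(F)(F)F)cc3)ccc2n1`: 140 nM in a functional assay on HEK293 cells for activation of melanin-concentrating hormone receptor 1 (Rattus norvegicus), read by inositol phosphate accumulation; on this read-out lower numbers stand for an effect already at smaller amounts and higher numbers for an effect only at larger amounts of compound.
Compound 2 `CC1CCN(c2ccc3cc(NC(=O)CCc4ccc(C(F)(F)F)cc4)ccc3n2)C1`: 400 nM in this assay.
Compound 3 `O=C(CCc1ccc(C(F)(F)F)cc1)Nc1ccc2nc(N3CCC4(CCNC4)C3)ccc2c1`: 140 nM in this assay.

Compound 3 stands level with compound 1 at the digits printed, the two together the lowest of the three numbers; the only separation beyond the scatter in this set is a 2.9-fold lower number from compound 2 to compound 3 (0.46 log units; beyond the scatter).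

Compound 4 `CCN(CC)c1ccc2cc(NC(=O)CCc3ccc(C(F)(F)F)cc3)ccc2n1` differs from compound 3 in one place: a group of 5 heavy atoms (4 carbon, 1 nitrogen; no ring) in place of a group of 9 heavy atoms (7 carbon, 2 nitrogen; 2 five-membered non-aromatic rings with 1 hetero atom each), on an aromatic carbon. Going by the values given here, two measured steps bear on this. The first, no change at the digits printed from compound 1 to compound 3 (within the scatter), sets an acyclic amino group against the spiro group with no change at all. The second, a 2.9-fold higher number from compound 1 to compound 2 (0.46 log units; beyond the scatter), is modest and concerns a ring amine, not the acyclic kind entering here. The return to an acyclic amine is therefore expected to bring no step beyond the scatter, a 1.1-fold higher number from compound 3 to compound 4 (0.03 log units; within the scatter). Compound 4 is estimated at 150 nM, within 60 nM to 400 nM.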

Compound 4, half-maximal effective concentration: 830 nM
Compound 4: the middle estimate sits 5.5-fold (0.74 log units) below what was measured, and the stated range ends below it.
By their numbers in this assay, from the lowest: compounds 1 and 3 (each within the scatter of the next); then compound 2; then compound 4.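

On the aromatic carbon next to the ring nitrogen, two acyclic amines part clearly in this assay: diethylamino in place of isopropyl(methyl)amino gives (a 5.9-fold higher number from compound 1 to compound 4 (0.77 log units; beyond the scatter)). Diethylamino also gives (a 5.9-fold higher number from compound 3 to compound 4 (0.77 log units; beyond the scatter)) and (a 2.1-fold higher number from compound 2 to compound 4 (0.32 log units; beyond the scatter)), so having no ring does not sort this set: compound 1 goes against that reading, level with compound 3. No measurement at hand accounts for these steps.

Open, as far as these compounds go, is where dimethylamino or piperazin-1-yl would fall at this position, and whether the second nitrogen in the group of compound 3 contributes to its number.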